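Cyclopropylmethoxy in place of methoxy across two cores

A few compounds are considered here, and "the series" means these few. Any claim that something is new, unique, unknown or untested is made for them only; others in the source may bear on it.

Compound 1 `COc1ccc(-c2nn3c(NC4CCCC4)nccc3c2-c2ccnc(NC3CCCC3)n2)cc1` and compound 2 `c1cc(-c2c(-c3ccc(OCC4CC4)cc3)nn3c(NC4CCCC4)nccc23)nc(NC2CCCC2)n1` share one core; compound 3 `COc1ccc(-c2nn3c(NC4CCCC4)cccc3c2-c2ccnc(NC3CCCC3)n2)cc1` and compound 4 `c1cc(NC2CCCC2)n2nc(-c3ccc(OCC4CC4)cc3)c(-c3ccnc(NC4CCCC4)n3)c2c1` share another. How the core of compound 1 and the core of compound 3 differ is not broken down here. All are examined in an ADME assay on Vero cells (Chlorocebus sabaeus) for cytotoxicity; on this read-out higher numbers stand for lower toxicity in this test and lower numbers for higher toxicity in this test.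

In this assay compound 1 gives > 40000 nM, which is a limit of the assay and not a number. In this assay compound 2 gives > 40000 nM, likewise a limit. In this assay compound 3 gives > 100000 nM, again a limit rather than a number. Two of the three values sit at the limit of > 40000 nM in this assay, at which 2 of the 3 values shown sit, and one at the limit of > 100000 nM in this assay, at which 1 of the 3 values shown sits.

The change from compound 1 to compound 2 is cyclopropyl in place of hydrogen on a saturated chain carbon bound to an oxygen on an aromatic ring. Its step in this assay reads a step that the two limits leave unreadable from compound 1 to compound 2, so neither direction nor size of the step can be taken from the pair. Compound 4 carries the same change on the core of compound 3: cyclopropyl in place of hydrogen on a saturated chain carbon bound to an oxygen on an aromatic ring.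

Compound 4 is therefore expected to remain at a limit in this assay, since compound 3 already sits at the limit of > 100000 nM in this assay, at which 1 of the 3 values shown sits, and the same change left compound 2 at the limit of > 40000 nM in this assay, at which 2 of the 3 values shown sit. The expected step from compound 3 to compound 4 is small, a number no higher from compound 3 to compound 4 (the limit leaves the size open). Compound 4 is estimated at 100000 nM, with a range from 40000 nM to 300000 nM should a number be reached at all.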

Compound 4, half-maximal cytotoxic concentration: > 40000 nM
Compound 4: a limit, no number; the forecaster's own chance of this, stated with the estimate: 80%; the middle value lies beyond the limit too.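

Compound 3 and compound 4 both stand at limits, not numbers, in this assay, so no step can be read between them. The compounds shown leave open whether methoxy to cyclopropylmethoxy shifts the half-maximal cytotoxic concentration on either core, and where that concentration lies for any of the four compounds.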